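The compounds below may be only part of what the source reports. "The series", "measured", "known", "first", "only" and "open" are said of these compounds alone.

Measured compounds:
Compound 1, `COc1ccc(N2CCN(CN3C(=O)/C(=N\NC(=S)NO)c4cc(F)ccc43)CC2)cc1`, gives 260000 nM.
Compound 2, `CONC(=S)N/N=C1\C(=O)N(CN2CCN(c3c(F)cc4c(=O)c(C(=O)O)cn(C5CC5)c4c3OC)CC2C)c2ccc(C)cc21`, gives 154000 nM.
Compound 3, `CCn1cc(C(=O)O)c(=O)c2cc(F)c(N3CCN(CN4C(=O)/C(=N\NC(=S)NOC)c5cc(F)ccc54)CC3)cc21`, gives 144000 nM.

In an ADME assay on MT4 cells (Homo sapiens) for cytotoxicity, read by spectrophotometry, with a stated time of 5 days (on this read-out higher numbers stand for lower toxicity in this test and lower numbers for higher toxicity in this test), compound 3 gives 144000 nM. Its number sits within the usual scatter of that of compound 2, which gives 154000 nM, and also of that of compound 1, which gives 260000 nM; the three values cannot be told apart on this assay. Among the compounds with values here, no single-point step between measured compounds is available, so the size of any step here is not known from the data.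

Compound 4, `CCn1cc(C(=O)O)c(=O)c2cc(F)c(N3CCN(CN4C(=O)/C(=N\NC(=S)NOC)c5cc(C)ccc54)CC3)cc21`, has not yet been measured. It differs from compound 3 in one place: methyl in place of fluoro on an aromatic carbon. Because compound 3 gives 144000 nM, compound 4 is expected to show a step no larger than the scatter, in no particular direction, of a 1.0-fold higher number from compound 3 to compound 4 (0.02 log units; within the scatter). Compound 4 is therefore estimated to give 150000 nM, within a range from 70000 nM to 320000 nM.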

Compound 4, half-maximal cytotoxic concentration: 238000 nM
Beside the measured number, compound 4's estimate is 1.6-fold (0.20 log units) below it, and the stated range covers the measured number.
By their numbers in this assay, from the lowest: compounds 3, 2, 4 and 1 (each within the scatter of the next).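

In this assay, within the data shown here, methyl in place of fluoro gives a 1.7-fold higher number from compound 3 to compound 4 (0.22 log units; within the scatter), the first single-point step in this set. Among these compounds, at this aromatic carbon, meta to a fused ring and para to a fused ring, the two groups therefore cannot be told apart on this read-out, something the earlier compounds, which differ in more than one place, could not show. No measured evidence bears on this result.

On these data alone, whether an amine or a nitrile on the same aromatic carbon would also stay within the scatter remains open. As far as these compounds go, it is also open whether methyl in place of fluoro would give a similar step on the core of compound 1 or the core of compound 2.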